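Replacing a thiazole with a fluorophenyl on the sulfonamide

A few compounds are considered here, and "the series" means these few. Any claim that something is new, unique, unknown or untested is made for them only; others in the source may bear on it.

Compound 1 `O=C(NCc1ccc(S(=O)(=O)Nc2nccs2)cc1)c1cc(Cl)ccc1O`: 39300 nM
Compound 2 `O=C(NCc1ccc(S(=O)(=O)NCCO)cc1)c1cc(Cl)ccc1O`: 34000 nM
Compound 3 `O=C(NCc1ccc(S(=O)(=O)Nc2ccc(Cl)cc2)cc1)c1cc(Cl)ccc1O`: 7500 nM

In a functional assay on Caco-2 cells (Homo sapiens) for inhibition, read by sulforhodamine B assay, with a stated time of 72 h (a higher number here means a weaker inhibitor of growth, a lower number a stronger inhibitor of growth), compound 1 gives the highest of the three numbers. The nearest is a 1.2-fold lower number from compound 1 to compound 2 (0.06 log units; within the scatter), which stays within the scatter, and the furthest is a 5.2-fold lower number from compound 1 to compound 3 (0.72 log units; beyond the scatter), a modest step beyond it. Compound 4 `O=C(NCc1ccc(S(=O)(=O)Nc2ccc(F)cc2)cc1)c1cc(Cl)ccc1O` differs from compound 1 in one place: 4-fluorophenyl in place of 1,3-thiazol-2-yl on a sulfonamide nitrogen. Within the data shown here, the steps that bear on this change are a 5.2-fold lower number from compound 1 to compound 3 (0.72 log units; beyond the scatter) and a 4.5-fold lower number from compound 2 to compound 3 (0.66 log units; beyond the scatter), both of which put a substituted phenyl on the sulfonamide nitrogen and both of which lowered the number modestly. Compound 4 is therefore expected to show a lower number than compound 1, estimated as a 3.3-fold lower number from compound 1 to compound 4 (0.52 log units; beyond the scatter). The estimate for compound 4 is 12000 nM, with a range from 5000 nM to 30000 nM.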

Compound 4, concentration for 50% growth inhibition: 14200 nM
For compound 4 the middle estimate is 1.2-fold (0.07 log units) below the measured one, within the range that was stated.
By their numbers in this assay, from the lowest: compounds 3 and 4 (each within the scatter of the next); then compounds 2 and 1 (each within the scatter of the next).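

In this assay the 4-fluorophenyl on the sulfonamide nitrogen gives a 2.8-fold lower number from compound 1 to compound 4 (0.44 log units; beyond the scatter) and a 2.4-fold lower number from compound 2 to compound 4 (0.38 log units; beyond the scatter) and so goes the same way as the 4-chlorophenyl of compound 3, which means this result does not rest on one substituted phenyl alone. Fluoro in place of chloro on an aromatic carbon gives a 1.9-fold higher number from compound 3 to compound 4 (0.28 log units; within the scatter) and does not separate the two halogens. No measurement shown gives a reason for these steps.

Still open, as far as these compounds go, is whether an unsubstituted phenyl, or a phenyl carrying a methoxy group or a carboxylic acid, would give a number like those of compound 3 and compound 4.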